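Amide Substituent Changes on a Shared Core

The compounds below may be only part of what the source reports. "The series", "measured", "known", "first", "only" and "open" are said of these compounds alone.

Measured compounds:
compound 1, `O=C(NCc1ccccc1)c1c(O)c2cccnc2n(-c2ccccc2)c1=O`: 11.3%
compound 2, `O=C(Nc1cccc(Cl)c1)c1c(O)c2cccnc2n(-c2ccccc2)c1=O`: 13.4%

In a functional assay on the whole organism for inhibition, with Rattus norvegicus as the target, read by cytopathic effect and paw edema, at a dose of 100 mg/kg by the oral route (on this read-out lower numbers stand for less inhibition and higher numbers for more inhibition at the one dose given (going by the name of the read-out)), compound 1 gives 11.3% and compound 2 gives 13.4%. Going by the values given here, compound 2 is not separated from compound 1 on these numbers: the only measured step, a number 2.1 percentage points higher from compound 1 to compound 2 (within the scatter), lies within the scatter, so the two compounds cannot be ranked against each other.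

Compound 3, `O=C(NCc1ccncc1)c1c(O)c2cccnc2n(-c2ccccc2)c1=O`, is the next compound to be measured in this assay. It differs from compound 2 in one place: (pyridin-4-yl)methyl in place of 3-chlorophenyl on an amide-type nitrogen. Among the compounds with values here, the one measured step, from a benzyl group to a 3-chlorophenyl group on the same amide-type nitrogen, was small and within the scatter. No measured step covers a change to a (pyridin-4-yl)methyl group, so the data give no reason to expect a move beyond the scatter in either direction. Compound 3 is therefore expected to show a step of about a number 1.4 percentage points lower from compound 2 to compound 3 (within the scatter) in this assay. The estimate for compound 3 is 12%, with a range from 3% to 22%.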

Compound 3, a percentage reported as inhibition, in the whole organism at one dose (the size of the read-out at that dose, not a potency): 15.4%
Estimate against measurement, compound 3: 3.4 percentage points below, and the stated range covers the measured number.
By their numbers in this assay, from the lowest: compounds 1, 2 and 3 (each within the scatter of the next).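

In this assay, (pyridin-4-yl)methyl in place of 3-chlorophenyl on the amide-type nitrogen gives a number 2 percentage points higher from compound 2 to compound 3 (within the scatter) and pyridin-4-yl in place of phenyl on the saturated chain carbon bound to that nitrogen gives a number 4.1 percentage points higher from compound 1 to compound 3 (within the scatter) and neither step leaves the scatter. Going by these compounds alone, this place on the shared core has now carried three groups, one of them with a hetero atom in its six-membered aromatic ring and a hydrogen-bond acceptor, and no pair among compound 1, compound 2 and compound 3 can be ranked on this read-out. No measured evidence bears on why these numbers lie so close together.

The compounds shown leave open whether any group on this amide-type nitrogen can move the number beyond the scatter at the one oral dose given. As far as these compounds go, a longer chain ending in an amine or a carboxylic acid would test this place further, and what changes elsewhere on the shared core would do also remains unknown from these compounds.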